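The source may hold more compounds than are shown below. What is called first, only, known or untested is meant among the compounds shown, and "the series" means these compounds.

Compound 1 `O=c1c2cccnc2sn1-c1ccc([N+](=O)[O-])cc1` and compound 2 `O=c1c2cccnc2sn1-c1ccc(Br)cc1` share one core; in an assay for inhibition of histone acetyltransferase KAT2B (Homo sapiens), read by fluorescence (a higher number here means a weaker inhibitor, a lower number a stronger inhibitor), compound 1 gives 4100 nM and compound 2 gives 4430 nM. The change between them, (bromo in place of nitro on an aromatic carbon), makes a 1.1-fold higher number from compound 1 to compound 2 (0.03 log units; within the scatter). Compound 3 `Cc1cnc2sn(-c3ccc([N+](=O)[O-])cc3)c(=O)c2c1` carries a different core, the difference being (methyl in place of hydrogen on an aromatic carbon); in this assay compound 3 gives 15300 nM, which is a 3.7-fold higher number from compound 1 to compound 3 (0.57 log units; beyond the scatter). Compound 4 `Cc1cnc2sn(-c3ccc(Br)cc3)c(=O)c2c1` is not yet measured. It differs from compound 3 by bromo in place of nitro on an aromatic carbon, the same change as seen between compound 1 and compound 2, at a place described in identical words. For compound 4 the expected step is a 1.1-fold higher number from compound 3 to compound 4 (0.03 log units; within the scatter). This rests on a 1.1-fold higher number from compound 1 to compound 2 (0.03 log units; within the scatter) lying within the scatter, taken to carry over to the core of compound 3. For compound 4 the estimate in this assay is 16500 nM, expected between 8000 nM and 34000 nM.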

Compound 4, half-maximal inhibitory concentration: 2990 nM
Compound 4: middle estimate off by 5.5-fold (0.74 log units), on the high side; the whole stated range lies above it.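

In this assay, bromo in place of nitro on an aromatic carbon gives a 5.1-fold lower number from compound 3 to compound 4 (0.71 log units; beyond the scatter), so this step does not carry over unchanged from the core of compound 1 to the core of compound 3: the same change on two cores in this assay, a 1.1-fold higher number (0.03 log units; within the scatter) from compound 1 to compound 2 and a 5.1-fold lower number (0.71 log units; beyond the scatter) from compound 3 to compound 4, 5.5-fold (0.74 log units) apart, beyond the scatter of two such steps. Methyl in place of hydrogen on an aromatic carbon also depends on the group it is paired with, giving a 1.5-fold lower number from compound 2 to compound 4 (0.17 log units; within the scatter) with bromo present, unlike the step seen with nitro: the same change on two cores in this assay, a 3.7-fold higher number (0.57 log units; beyond the scatter) from compound 1 to compound 3 and a 1.5-fold lower number (0.17 log units; within the scatter) from compound 2 to compound 4, 5.5-fold (0.74 log units) apart, beyond the scatter of two such steps. The two changes are therefore not independent in these four compounds, but this shows neither the cause nor how they behave on any other core.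

From the compounds shown here alone, it remains open whether an amine or a carboxylic acid in place of bromo or nitro would follow either result. Going by these compounds, it is also open whether a longer chain in place of the methyl would behave as the methyl does.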